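The compounds below may be only part of what the source reports. "The series", "measured", "known", "first", "only" and "open" are said of these compounds alone.

Compound 1, `C=C[C@@](C)(/C=C/c1ccc(OCc2ccccc2)cc1)CCC=C(C)C`: in a functional assay on HepG2 cells (Homo sapiens) for cytotoxicity, with a stated time of 72 h (a higher number here means that more compound is needed for the effect, a lower number that less compound is needed), compound 1 gives > 52000 nM, which is a limit of the assay and not a number.
Compound 2, `C=C[C@](C)(CCCC(C)C)CCc1ccc(O)cc1`: in this assay compound 2 gives > 52000 nM, again a limit rather than a number.
Compound 3, `C=C[C@@](C)(/C=C/c1ccc(O)c(/C=C/C(=O)OCc2ccccc2)c1)CCC=C(C)C`: in this assay compound 3 gives > 52000 nM, also a limit rather than a number.

Within the data shown here, compound 1 therefore stands nowhere in particular among the three: every value shown is a limit, as summed up by the limit of > 52000 nM in this assay, at which 3 of the 3 values shown sit, so no compound can be set above or below another, and no step between two measured compounds can be read off.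

The unmeasured compound 4, `C=C[C@@](C)(/C=C/c1ccc(-c2cccc(F)c2)cc1)CCC=C(C)C`, differs from compound 1 in one place, (3-fluorophenyl in place of benzyloxy on an aromatic carbon). The shared core of compound 1 is kept whole; only the group at that aromatic carbon is exchanged.

Among the measured compounds shown here, with all three measured values sitting at the limit, there is no measured step to lean on. The expectation is that the exchange moves the result by no step beyond the scatter of this assay, and that compound 4 also ends up at the limit. The step estimated as a step that the limit leaves unreadable from compound 1 to compound 4 is expected to be essentially none. Compound 4 is expected to give about 60000 nM, with a range from 20000 nM to 200000 nM.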

Compound 4, half-maximal effective concentration: > 52000 nM
Compound 4 gave a limit, no number (the forecaster's own chance of this, stated with the estimate: 80%); the middle value does not contradict the limit.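

Compound 1 and compound 4 both give a limit and not a number, and no step can be read between them, so the exchange of benzyloxy for 3-fluorophenyl has no readable size. The compounds shown leave open whether any change to these structures shifts the result in this assay, with a single limit holding all of them: the limit of > 52000 nM in this assay, at which 4 of the 4 values shown sit.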